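A few compounds are considered here, and "the series" means these few. Any claim that something is new, unique, unknown or untested is made for them only; others in the source may bear on it.

Compound 1 `ClCc1ccccc1Cn1cnc2c(Cl)nc(Cl)nc21` and compound 2 `ClCc1cccc(Cn2cnc3c(Cl)nc(Cl)nc32)c1` share one core and differ only in where the chloromethyl group sits on the benzyl ring. Among the compounds with values here, in a functional assay on UACC-62 cells (Homo sapiens) for cytotoxicity, read by sulforhodamine B assay, with a stated time of 48 h (a higher number here means a weaker inhibitor of growth, a lower number a stronger inhibitor of growth), compound 1 gives 2630 nM, the lower of the two numbers measured so far, while compound 2 gives 3460 nM; the gap separating them lies within the usual scatter, so the two cannot be told apart on these numbers.

Compound 3 `Nc1nc(Cl)c2ncn(Cc3ccccc3CCl)c2n1` has not yet been measured. Its change from compound 1 is amino in place of chloro on an aromatic carbon, on an aromatic carbon of the core that lies between two ring nitrogen atoms; the chloromethyl-benzyl part is untouched. Within the data shown here, no measured pair shows what this particular swap does in this assay, so there is nothing in the existing data to anchor its size. On that basis the expectation for compound 3 is a step of a 1.5-fold higher number from compound 1 to compound 3 (0.18 log units; within the scatter) that is small, most likely no larger than the scatter, with a slight lean toward a higher number. The estimate for compound 3 is therefore 4000 nM, with a plausible range from 1500 nM to 12000 nM.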

Compound 3, concentration for total growth inhibition: 4370 nM
The estimate for compound 3 lay 1.1-fold (0.04 log units) below the measured number; the measured number falls inside the stated range.
By their numbers in this assay, from the lowest: compounds 1, 2 and 3 (each within the scatter of the next).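

In this assay, within the data shown here, the swap of chloro for amino can be read directly as a 1.7-fold higher number from compound 1 to compound 3 (0.22 log units; within the scatter), the first direct reading of any change at this aromatic carbon between two ring nitrogen atoms. The step shows that a chloro group, with no hydrogen-bond donor, can give way here to an amino group, with one, without the number moving beyond the usual scatter of the measurement. Nothing available explains why this step is so small, so the result stands as an observation with no cause attached.

A single swap cannot show whether every group at this carbon would behave the same way, and a methoxy or a dimethylamino group here might or might not give a step beyond the scatter. The compounds shown also leave open how much the remaining chloro group on the core and the chloromethyl group on the benzyl ring contribute to the growth inhibition, since both are still present in compound 1, compound 2 and compound 3, and a plain methyl group in place of chloromethyl would be one way to ask.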